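Working notes: amino in place of nitro

This account rests on a few compounds, and the source may have more. Where it says the series, first, only, none or still open, it means among the compounds named here.

Measured in a functional assay on HeLa cells (Homo sapiens) for antiproliferative activity, read by MTT assay, with a stated time of 72 h (on this read-out higher numbers stand for weaker inhibition and lower numbers for stronger inhibition), so far:
- compound 1 (`COc1cc(-c2nccn2C(C)C)cc(OC)c1OC`) gives > 100000 nM as a limit of the assay
- compound 2 (`COc1ccc(NC(=O)c2cc(OC)c(OC)c(OC)c2)cc1[N+](=O)[O-]`) gives 38700 nM as a measured number

The value of compound 1 is a limit and not a number. Of the two measured compounds, only compound 2 has an actual number, and this is the starting point for the next step.

Compound 3 (`COc1ccc(NC(=O)c2cc(OC)c(OC)c(OC)c2)cc1N`) is not yet measured. It differs from compound 2 in one place, with amino in place of nitro on an aromatic carbon, ortho to a methoxy group and meta to a large group (amino in place of nitro on an aromatic carbon).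

Within the data shown here, the series holds no measured step that could size this change, so the expectation is loose. A moderate move towards stronger inhibition in this assay is expected, somewhat beyond the scatter, since compound 2 at 38700 nM leaves room on that side. The expected change is a 2.2-fold lower number from compound 2 to compound 3 (0.33 log units; beyond the scatter) on this estimate. For compound 3 the estimated value is 18000 nM with an expected range from 3000 nM to 80000 nM for now.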

Compound 3, half-maximal inhibitory concentration: 4100 nM
The estimate for compound 3 lay 4.4-fold (0.64 log units) above the measured number; the range from low to high includes it.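

In this assay, among these compounds, the position ortho to a methoxy group and meta to a large group responds clearly to what it carries: amino in place of nitro gives a 9.4-fold lower number from compound 2 to compound 3 (0.97 log units; beyond the scatter), the first sized step and one beyond the scatter. Before this, the series offered one number and one limit with no link between them, so nothing could be said about this position; it is now known to matter for this read-out, and the smaller amino, which brings a hydrogen-bond donor where nitro has none, is the better of the two groups. The compounds shown do not tell whether size, the donor or some other difference between the two groups carries the step, and no measurement here bears on that.

Still open, from the compounds shown here alone, is whether the amino group itself matters or mainly the departure of nitro, which a hydroxyl, a methylamino or an acetamide at the same position would help to separate. Also open, going by these compounds, is whether the step holds when the neighbouring methoxy group gives way to an ethoxy or a hydroxyl.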